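From 1,3-thiazol-5-yl to 1,2-thiazol-4-yl

The source may hold more compounds than are shown below. What is called first, only, known or untested is meant among the compounds shown, and "the series" means these compounds.

Measured compounds:
- compound 1 `CC/C(=C(/c1ccc(/C=C/C(=O)O)cc1)c1ccc2nnnn2c1)c1ccccc1`: > 500 nM (a limit)
- compound 2 `CC/C(=C(/c1ccc(/C=C/C(=O)O)cc1)c1ccc2scnc2c1)c1ccccc1`: 90 nM
- compound 3 `CC/C(=C(/c1ccc(/C=C/C(=O)O)cc1)c1ccc(-c2cncs2)cc1)c1ccccc1`: 31 nM

In a functional assay on MCF7 cells (Homo sapiens) for antiproliferative activity, read by CellTiter-Glo, with a stated time of 5 days (on this read-out lower numbers stand for stronger inhibition and higher numbers for weaker inhibition), compound 2 gives 90 nM and compound 3 gives 31 nM as the lower of the two exact numbers. Compound 1 gives > 500 nM as a limit of the assay and not a number. Compound 4 `CC/C(=C(/c1ccc(/C=C/C(=O)O)cc1)c1ccc(-c2cnsc2)cc1)c1ccccc1` is still unmeasured. It carries 1,2-thiazol-4-yl in place of 1,3-thiazol-5-yl on an aromatic carbon and so has the same atoms as compound 3, joined differently. Going by the values given here, the one measured step is an at least 5.5-fold lower number from compound 1 to compound 2 (0.74 log units; beyond the scatter) and it exchanged a whole ring group, a much larger change, so it bears only loosely here. In this assay the expected step is a 1.1-fold higher number from compound 3 to compound 4 (0.05 log units; within the scatter) and it should probably stay within the scatter, with no favoured direction. For compound 4 the estimated value is 35 nM with 12 nM to 110 nM as its expected range.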

Compound 4, half-maximal inhibitory concentration: 120 nM
For compound 4 the middle estimate is 3.4-fold (0.54 log units) below the measured one; measured number above the stated range.
By their numbers in this assay, from the lowest: compound 3; then compounds 2 and 4 (each within the scatter of the next). At a limit, above all of these: compound 1.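

With no change in the atoms, putting 1,2-thiazol-4-yl in place of 1,3-thiazol-5-yl on an aromatic carbon para to a large group gives a 3.9-fold higher number from compound 3 to compound 4 (0.59 log units; beyond the scatter) in this assay and so shows that how the ring atoms are joined matters at this position. The earlier step exchanged a whole ring group and could not separate this from a change of atoms. Nothing measured here explains the difference between these two rings. Still open, on these data alone, is where an oxazole or a pyrazole ring, or a simple amine, would fall at this position.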